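The source may hold more compounds than are shown below. What is called first, only, known or untested is meant among the compounds shown, and "the series" means these compounds.

Compound 1 `CC(C)C[C@H](N)c1cc(C(F)(F)F)ccc1N1CCN(C(=O)COc2ccc(Cl)cc2)CC1` gives 2900 nM in an assay on HEK293 cells for displacement of a labelled ligand from Melanocortin receptor 4 (Homo sapiens); a higher number here means a weaker inhibitor, a lower number a stronger inhibitor. Compound 2 `CC(C)C[C@H](N)c1cc(C(F)(F)F)ccc1N1CCN(C(=O)COc2ccc(O)cc2)CC1` gives 4600 nM in this assay, a step of a 1.6-fold higher number from compound 1 to compound 2 (0.20 log units; within the scatter). Compound 3 `CC(C)C[C@H](N)c1cc(C(F)(F)F)ccc1N1CCN(C(=O)CCC(=O)N(C)C)CC1` stands only at a limit of this assay, > 10000 nM, so no number is known for it (the limit of > 10000 nM in this assay, at which 1 of the 3 values shown sits). Compound 4 `Cc1cc(CC(C)C(=O)N2CCN(c3ccc(C(F)(F)F)cc3[C@@H](N)CC(C)C)CC2)ccc1Cl` differs from compound 3 by 1-(4-chloro-3-methylbenzyl)ethyl in place of 2-(dimethylcarbamoyl)ethyl on a carbonyl carbon. For the measured compounds named here, the steps that bear on this are an at least 3.4-fold higher number from compound 1 to compound 3 (0.53 log units; beyond the scatter) and an at least 2.1-fold higher number from compound 2 to compound 3 (0.33 log units; beyond the scatter), both worsening when 4-chlorophenoxy or 4-hydroxyphenoxy gave way to (dimethylcarbamoyl)methyl. Since compound 4 brings an aromatic ring carrying chloro back onto this carbonyl carbon, the expected step is an at least 4.0-fold lower number from compound 3 to compound 4 (0.60 log units; beyond the scatter), a return to a measurable number. Compound 4 is therefore estimated at 2500 nM, within 700 nM to 9000 nM.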

Compound 4, inhibition constant: 71 nM
Beside the measured number, compound 4's estimate is 35-fold (1.55 log units) above it, outside the stated range (below it).
By their numbers in this assay, from the lowest: compound 4; then compounds 1 and 2 (each within the scatter of the next). At a limit, above all of these: compound 3.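

On this carbonyl carbon, the aromatic ring carrying chloro is not enough on its own: 1-(4-chloro-3-methylbenzyl)ethyl in place of (4-chlorophenoxy)methyl gives a 41-fold lower number from compound 1 to compound 4 (1.61 log units; beyond the scatter) and in place of (4-hydroxyphenoxy)methyl gives a 65-fold lower number from compound 2 to compound 4 (1.81 log units; beyond the scatter) in this assay for the same core. Compound 3 stands only at a limit: the limit of > 10000 nM in this assay, at which 1 of the 4 values shown sits. Measured against that limit, the change gives an at least 140-fold lower number from compound 3 to compound 4 (2.14 log units; beyond the scatter) as a bound, not a measured size.

Which feature carries the improvement stays open, since the ring methyl, the chain branch and the ether oxygen change together here. Also open, from the compounds shown here alone, is whether a cyclohexyl ring or a carboxylic acid could replace the aromatic ring.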